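Fluorinated stilbene series: hydroxy to amino on the ring

This account rests on a few compounds, and the source may have more. Where it says the series, first, only, none or still open, it means among the compounds named here.

Three compounds of the series have numbers in a functional assay on cells (Endothelial cell, Bos taurus) for antiproliferative activity; on this read-out lower numbers stand for stronger inhibition and higher numbers for weaker inhibition. Compound 1 `COc1ccc(/C=C(/F)c2cc(OC)c(OC)c(OC)c2)cc1O` gives 1700 nM in this assay, the lowest of the three. Compound 2 `COc1ccc(/C(F)=C/c2cc(OC)c(OC)c(OC)c2)cc1O` gives 26600 nM in this assay. The two are built from the same atoms joined differently; the difference between the two cores is not broken down here. Compound 3 `COc1ccc(/C(F)=C/c2cc(OC)c(OC)c(OC)c2)cc1N` gives 111000 nM in this assay.

Compound 3 arises from compound 2 by one change, (amino in place of hydroxy on an aromatic carbon), and the step was a 4.2-fold higher number from compound 2 to compound 3 (0.62 log units; beyond the scatter).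

Compound 4 `COc1ccc(/C=C(/F)c2cc(OC)c(OC)c(OC)c2)cc1N` is not yet measured in this assay. It arises from compound 1 by amino in place of hydroxy on an aromatic carbon. For the measured compounds named here, the place line for this change reads the same, word for word, as the one for the change from compound 2 to compound 3, so it is the same change, made on the core of compound 1 instead of the core of compound 2. Among the compounds shown it occurs twice in all.

Going by the values given here, with only one measured instance of the change, the expectation rests on that single step. The step from compound 1 to compound 4 is expected to be about a 4.1-fold higher number from compound 1 to compound 4 (0.61 log units; beyond the scatter), following the step seen from compound 2 to compound 3, which was beyond the scatter. The spread is set wide, since the two cores are joined differently and a step need not repeat in size. In this assay compound 4 is therefore estimated at 7000 nM, with a range from 2500 nM to 20000 nM expected.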

Compound 4, half-maximal inhibitory concentration: 2000 nM
The estimate for compound 4 lay 3.5-fold (0.54 log units) above the measured number; measured number below the stated range.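

In this assay, amino in place of hydroxy on the core of compound 1 gives a 1.2-fold higher number from compound 1 to compound 4 (0.07 log units; within the scatter), so on this core the numbers with the two groups cannot be told apart. The size of the step therefore does not carry from one core to the other, and the step seen on the core of compound 2 is no safe guide to the core of compound 1: the same change on two cores in this assay, a 4.2-fold higher number (0.62 log units; beyond the scatter) from compound 2 to compound 3 and a 1.2-fold higher number (0.07 log units; within the scatter) from compound 1 to compound 4, 3.5-fold (0.55 log units) apart, beyond the scatter of two such steps. This shows that the outcome of the change depends on the core among the compounds shown, but with one pair on each core it does not show which difference between the cores sets the gap, nor which of the two steps would be the more typical on a further core.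

Open, from the compounds shown here alone, is how other groups at this place, such as a methylamino group, an acetamide or a carboxylic acid, would read on either core, and whether they too would give steps that differ between the cores. Also open, going by these compounds, is whether the gap between the two steps would hold in any read-out other than this assay.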